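The source may hold more compounds than are shown below. What is called first, only, known or untested is meant among the compounds shown, and "the series" means these compounds.

Compound 1 `COc1ccc(N(C)c2nc(C)nc3ccccc23)cc1C(=O)OCCCCC[Se]C#N`: 592 nM in a functional assay on A549 cells (Homo sapiens) for inhibition, read by MTT assay, with a stated time of 48 h; a higher number here means a weaker inhibitor, a lower number a stronger inhibitor
Compound 2 `COc1ccc(N(C)c2nc(C)nc3ccccc23)cc1C(=O)OCCCC[Se]C#N`: 155 nM in this assay
Compound 3 `COc1ccc(N(C)c2nc(C)nc3ccccc23)cc1C(=O)OCCCCCC[Se]C#N`: 488 nM in this assay

Compound 2 stands lowest of the three numbers in this assay. From it, the step of a 3.1-fold higher number from compound 2 to compound 3 (0.50 log units; beyond the scatter) lies beyond the scatter, as does the step of a 3.8-fold lower number from compound 1 to compound 2 (0.58 log units; beyond the scatter) leading to it; between compound 1 and compound 3 the step of a 1.2-fold lower number from compound 1 to compound 3 (0.08 log units; within the scatter) stays within the scatter.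

Compound 4 `COc1ccc(N(C)c2nc(C)nc3ccccc23)cc1OCC[Se]C#N` differs from compound 2 as follows: a group of 6 heavy atoms (3 carbon, 1 nitrogen, 1 oxygen, 1 selenium; no ring) in place of a group of 10 heavy atoms (6 carbon, 1 nitrogen, 2 oxygen, 1 selenium; no ring), on an aromatic carbon. Both measured steps beyond the scatter concern only the length of the saturated chain carrying the selenium group within the shared core of compound 2, and the shorter chain gave the lower number. Neither step tests removal of the carbonyl or the change in the number of oxygens, so they bear on compound 4 only loosely. A step of modest size in this assay, direction uncertain, is expected; on the chain-length trend a somewhat lower number is not excluded, but the change is wider than any measured one, so the estimate is kept near compound 2 with a broad range.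

Compound 4 is expected to give 220 nM in this assay, between 60 nM and 800 nM, meaning an estimated step of a 1.4-fold higher number from compound 2 to compound 4 (0.15 log units; within the scatter).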

Compound 4, half-maximal inhibitory concentration: 13 nM
Estimate against measurement, compound 4: 17-fold (1.23 log units) above, outside the stated range (below it).
By their numbers in this assay, from the lowest: compound 4; then compound 2; then compounds 3 and 1 (each within the scatter of the next).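

In this assay, the group of 6 heavy atoms in place of the group of 10 heavy atoms on this aromatic carbon, ortho to a methoxy group, gives a 12-fold lower number from compound 2 to compound 4 (1.08 log units; beyond the scatter). This is a larger step than any seen among compound 1, compound 2 and compound 3, which differ only in the length of the saturated chain, so the linker as a whole matters more here than those chain-length steps indicated. Nothing available explains the size of this step.

The step removes the carbonyl, changes the number of oxygens and alters the chain at once, so the share of each change remains unresolved. A longer chain on the same oxygen link, or an amine in place of that oxygen, would help separate these contributions.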